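This account rests on a few compounds, and the source may have more. Where it says the series, first, only, none or still open, it means among the compounds named here.

Values in an ADME assay on a cell-free system (plasma, Homo sapiens) for protein binding, so far:
Compound 1 `CNc1nccc(N2CC[C@H](NC(=O)Nc3ccc(CN(C)C)c(C(F)(F)F)c3)C2)n1` gives 94.3%
Compound 2 `CNc1nccc(N2CC[C@H](NC(=O)Nc3cc(OC)cc(OC)c3)C2)n1` gives 98.1%
Compound 3 `CNc1nccc(N2CC[C@H](NC(=O)Nc3ccc(CN4CCC4)c(C(F)(F)F)c3)C2)n1` gives 86.3%

Of these three, compound 3 has the highest unbound fraction, and its gaps to both others lie beyond the scatter. Compound 1 is the nearest and compound 2 the furthest. Compound 4 `CNc1nccc(N2CC[C@H](NC(=O)Nc3ccc(CN4CCN(C)CC4)c(C(F)(F)F)c3)C2)n1` differs from compound 3 in one place (4-methylpiperazin-1-yl in place of azetidin-1-yl on a saturated chain carbon bound to an aromatic carbon): 4-methylpiperazin-1-yl replaces azetidin-1-yl on a saturated chain carbon bound to an aromatic carbon.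

One measured step changes the group at this same place: a 2.4-fold higher unbound fraction from compound 1 to compound 3 (0.38 log units; beyond the scatter), a modest step, with azetidin-1-yl replacing dimethylamino. Among the compounds with values here, no measured compound carries 4-methylpiperazin-1-yl, so this step suggests a size but does not settle the direction. Compound 3 sits at the unbound end of the three values with 86.3%, so a modest move back toward compound 1 is the more likely outcome. The expected change is a 1.4-fold lower unbound fraction from compound 3 to compound 4 (0.14 log units; within the scatter) in the estimate made here. For compound 4 the estimated value is 90%, with an expected range from 81% to 95.5% in this assay.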

Compound 4, plasma protein binding: 87.6%
Compound 4: middle estimate off by 1.2-fold (0.09 log units) (unbound fraction), on the low side; the measured number falls inside the stated range.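

In this assay, the place on a saturated chain carbon bound to an aromatic carbon now carries three groups, and the step a 1.1-fold lower unbound fraction from compound 3 to compound 4 (0.04 log units; within the scatter) shows that a six-membered ring with 2 hetero atoms can replace the four-membered azetidin-1-yl ring with no change beyond the scatter. The step a 2.2-fold higher unbound fraction from compound 1 to compound 4 (0.34 log units; beyond the scatter) is modest, like a 2.4-fold higher unbound fraction from compound 1 to compound 3 (0.38 log units; beyond the scatter), so among these three compounds the open-chain dimethylamino group of compound 1 stands apart, and compound 3 and compound 4 both lie on the less bound side of it. Nothing available here bears on the reason for this.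

Going by these compounds, how a pyrrolidin-1-yl or morpholin-4-yl group would read at this place remains open. On these data alone, it is also open whether a diethylamino group would fall with compound 1 or with compound 3 and compound 4.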